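The source may report more compounds than this note shows. Statements on the series, on what has been measured and on what is new or still open speak of the compounds shown alone.

Compound 1 `O=C1C(Nc2ccccc2)=CC(=O)c2c1nc1n2[C@H]2OC[C@@H](O)[C@H]2OC1`: > 4000 nM in a functional assay on MCF7 cells (Homo sapiens) for inhibition, read by sulforhodamine B assay; on this read-out lower numbers stand for stronger inhibition and higher numbers for weaker inhibition
Compound 2 `O=C1C=C(Nc2ccccc2F)C(=O)c2c1nc1n2[C@H]2OC[C@@H](O)[C@H]2OC1`: 3640 nM in this assay

Compound 1 reaches only a limit of the assay, > 4000 nM in this assay, so no number is known for it. Compound 2 gives 3640 nM in this assay, and this is the only number shown. The other result, that of compound 1, is a limit (the limit of > 4000 nM in this assay, at which 1 of the 2 values shown sits). Compound 3 `Cc1ccc(NC2=CC(=O)c3nc4n(c3C2=O)[C@H]2OC[C@@H](O)[C@H]2OC4)cc1C` differs from compound 2 in one place: 3,4-dimethylphenyl in place of 2-fluorophenyl on an amine nitrogen. Among the measured compounds shown here, no step between two measured compounds is available to calibrate this change, so the expectation rests on compound 2 alone, whose value of 3640 nM marks weak inhibition. The step of a 1.0-fold lower number from compound 2 to compound 3 (0.02 log units; within the scatter) is expected to be small and to stay within the scatter of repeated measurements. Compound 3 is therefore expected to give about 3500 nM in this assay, within a range from 1200 nM to 10000 nM, with a fair chance that the assay again reports only a limit.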

Compound 3, half-maximal inhibitory concentration: 2080 nM
Beside the measured number, compound 3's estimate is 1.7-fold (0.23 log units) above it; the range from low to high includes it.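

In this assay, putting 3,4-dimethylphenyl in place of 2-fluorophenyl on the amine nitrogen gives a 1.8-fold lower number from compound 2 to compound 3 (0.24 log units; within the scatter), so the two compounds cannot be told apart on this read-out. Among the compounds shown here, this is the first step that can be read at this position, and it shows that a ring with two methyl groups and no fluorine still gives a measured number in the same range, not a limit. No result shown gives a cause for this closeness.

Still open, going by these compounds, is whether any group on this amine nitrogen can move the number beyond the scatter, as both rings compared here are aromatic rings of carbon only. A ring bearing a carboxylic acid or an amine, or a longer chain in place of the ring, would put that question to the test.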